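Swapping an Aromatic Arm for a Piperidine Carbamate

This account rests on a few compounds, and the source may have more. Where it says the series, first, only, none or still open, it means among the compounds named here.

Compound 1, `OCC1CCN(c2nccnc2Oc2ccc(Nc3nc4ccccc4s3)cc2)CC1`, in a physicochemical assay for solubility, in phosphate buffer, at pH 7.4 (a lower number here means a less soluble compound, a higher number a more soluble compound), gives 6000 nM.
Compound 2, `OCC1CCN(c2cccnc2OC2CN(c3ccc4ccccc4n3)C2)CC1`, in this assay gives 189000 nM.
Compound 3, `OCc1cccc(-c2nccnc2OC2CN(c3ccc4ccccc4n3)C2)c1`, in this assay gives 29000 nM.

Among these three measured values, compound 3 stands second highest. Its nearest neighbour is compound 1, whose number is lower by a gap that exceeds the usual scatter, and the furthest is compound 2, whose number is higher, again by more than the scatter. Within the data shown here, no single-point step between two measured compounds is available, so the step from compound 3 to the unmeasured compound 4, `COC(=O)N1CCC(c2nccnc2OC2CN(c3ccc4ccccc4n3)C2)CC1`, has to be judged from the structures alone.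

The change is 1-(methoxycarbonyl)piperidin-4-yl in place of 3-(hydroxymethyl)phenyl on an aromatic carbon. The group that leaves carries one six-membered aromatic ring of carbon only and one hydrogen-bond donor; the group that enters carries one six-membered non-aromatic ring with one hetero atom, no donor and two acceptors.

The step from compound 3 to compound 4 in this assay is expected to be a modest rise, a 1.9-fold higher number from compound 3 to compound 4 (0.28 log units; within the scatter), partly because the non-aromatic piperidine-bearing compound 2 gives 189000 nM, the highest number seen here. Compound 4 is therefore estimated at 55000 nM, within a range from 14000 nM to 220000 nM.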

Compound 4, solubility: 138000 nM
For compound 4 the middle estimate is 2.5-fold (0.40 log units) below the measured one; measured number inside the range.
By their numbers in this assay, from the lowest: compound 1; then compound 3; then compounds 4 and 2 (each within the scatter of the next).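

On an aromatic carbon of a six-membered aromatic ring with 2 nitrogen, putting 1-(methoxycarbonyl)piperidin-4-yl in place of 3-(hydroxymethyl)phenyl gives a 4.8-fold higher number from compound 3 to compound 4 (0.68 log units; beyond the scatter) in this assay. Among these compounds, this is the first comparison here in which only one place differs, and it shows that the group at this position can move the number by more than the usual scatter, with the rest of the molecule unchanged. The swap changes several features together, replacing an aromatic ring with a non-aromatic one, removing the hydrogen-bond donor and adding a carbonyl, and nothing available explains the rise or assigns it to any one of these features.

The compounds shown leave open whether the piperidine ring or the methoxycarbonyl group on its nitrogen accounts for the step, a question that a piperidine with a free amine or an acetyl group in place of methoxycarbonyl could help to separate. They also leave open whether a plain phenyl, without the hydroxymethyl group, would stand nearer to compound 3 or to compound 4.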